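Aminothiazole series: methoxy removal on the aniline ring

The compounds below may be only part of what the source reports. "The series", "measured", "known", "first", "only" and "open" are said of these compounds alone.

Three measured members share a core of an aniline joined to a thiazole carrying a second phenyl ring. In an assay on isolated protein for inhibition of Polyunsaturated fatty acid 5-lipoxygenase (Homo sapiens), with stated times of 15 min and 10 min (on this read-out lower numbers stand for stronger inhibition and higher numbers for weaker inhibition), compound 1 `Oc1ccc(Nc2nc(-c3ccc(F)cc3)cs2)cc1` gives 700 nM. Compound 3 `Oc1cccc(Nc2nc(-c3ccccc3)cs2)c1` gives in this assay a value of 8300 nM. Compound 2 `COc1ccccc1Nc1nc(-c2ccc(Cl)cc2)cs1` stands highest of the three numbers, with 22500 nM in this assay; its nearest neighbour is compound 3, a gap beyond the usual scatter, and the gap to compound 1 is the widest of the set, also beyond the scatter.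

Compound 4 `Clc1ccc(-c2csc(Nc3ccccc3)n2)cc1` differs from compound 2 by hydrogen in place of methoxy on an aromatic carbon. Within the data shown here, no pair of measured compounds isolates this change, so its effect is not known from the data. The expectation rests on compound 2 holding the highest number, 22500 nM, while both other measured compounds sit lower. The step from compound 2 to compound 4 is expected to be a decrease beyond the scatter, a 3.8-fold lower number from compound 2 to compound 4 (0.57 log units; beyond the scatter). Compound 4 is estimated at 6000 nM, in a range from 1500 nM to 25000 nM.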

Compound 4, half-maximal inhibitory concentration: 5600 nM
Estimate against measurement, compound 4: 1.1-fold (0.03 log units) above; low and high end bracket the measured number.
By their numbers in this assay, from the lowest: compound 1; then compounds 4 and 3 (each within the scatter of the next); then compound 2.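

In this assay, the series now has its first comparison that differs in one place: a 4.0-fold lower number from compound 2 to compound 4 (0.60 log units; beyond the scatter), with hydrogen in place of methoxy on an aromatic carbon, ortho to a large group. The earlier compounds shown here differed in several places and could not isolate this position; the step shows that methoxy here is not required for inhibition, and that the compound carrying hydrogen has the lower number, beyond the scatter. Nothing on hand explains the size or direction of this step.

From the compounds shown here alone, the effect of an amine or an ethoxy group on this same carbon remains open, so a single step cannot show whether size or another feature of the group matters. Also open, going by these compounds, is whether the step would carry over to a compound without the chlorine.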